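A few compounds are considered here, and "the series" means these few. Any claim that something is new, unique, unknown or untested is made for them only; others in the source may bear on it.

Measured in a functional assay on HT-29 cells (Homo sapiens) for antiproliferative activity, read by MTT assay, with a stated time of 48 h; a lower number here means a stronger inhibitor, a higher number a weaker inhibitor:

- Compound 1 `Cc1ccc2nc(-c3ccc(Cl)cc3)cc(C(=O)OCc3ccccc3)c2c1` gives > 100000 nM, which is a limit of the assay and not a number.
- Compound 2 `Cc1ccc2nc(-c3ccc(F)cc3)cc(C(=O)OCc3ccccc3)c2c1` gives 15100 nM.

Among the measured compounds shown here, compound 2 holds the only true number so far, so it has no measured neighbour to rank against except a limit. Compound 3 `COc1ccc(-c2cc(C(=O)OCc3ccccc3)c3cc(C)ccc3n2)cc1` keeps the shared core and changes one group: methoxy in place of fluoro on an aromatic carbon. This is methoxy in place of fluoro on an aromatic carbon, para to a large group.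

For the measured compounds named here, one measured step bears on this change, and it concerns the same aromatic carbon: an at least 6.6-fold lower number from compound 1 to compound 2 (0.82 log units; beyond the scatter). Compound 1 is the only case so far with something other than fluoro there, and its result is the weaker one. A modest move towards weaker inhibition is therefore expected, an estimated 2.3-fold higher number from compound 2 to compound 3 (0.37 log units; beyond the scatter). For compound 3 the expected value in this assay is 35000 nM, with an estimated range from 9000 nM to 100000 nM.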

Compound 3, half-maximal inhibitory concentration: 17300 nM
Compound 3: middle estimate off by 2.0-fold (0.31 log units), on the high side; low and high end bracket the measured number.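

In this assay, going from 4-fluorophenyl to 4-methoxyphenyl changes little, a 1.1-fold higher number from compound 2 to compound 3 (0.06 log units; within the scatter), so at this aromatic carbon a methoxy group with its two heavy atoms gives a result that cannot be told apart from that of the single fluorine. Chloro now stands apart from both groups, an at least 5.7-fold lower number from compound 1 to compound 3 (0.76 log units; beyond the scatter), which means that the weak result of compound 1 does not hold for every replacement of fluoro. The value of compound 1 is a limit of the assay and not a number, so the true size of this step stays unknown: the limit of > 100000 nM in this assay, at which 1 of the 3 values shown sits.

The compounds shown compare only fluoro, chloro and methoxy at this carbon, so they cannot say whether chloro is a lone exception. From the compounds shown here alone, how an amine, a carboxylic acid or a longer chain such as butoxy would behave here also remains open.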